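The source may hold more compounds than are shown below. What is called first, only, known or untested is meant among the compounds shown, and "the series" means these compounds.

For the measured compounds named here, compound 2 `CNC(=O)c1cc(Oc2ccc(NC(=O)c3nn(-c4cccc(F)c4)c(=O)cc3C)cc2F)ccn1` is one of two compounds measured in a functional assay on HepG2 cells (Homo sapiens) for cytotoxicity, read by MTT assay, with a stated time of 72 h; on this read-out lower numbers stand for stronger inhibition and higher numbers for weaker inhibition; in it compound 2 gives 10200 nM, the highest of the two numbers. Its nearest neighbour is compound 1 `CNC(=O)c1cc(Oc2ccc(NC(=O)c3nn(-c4ccc(Br)cc4F)c(=O)cc3C)cc2F)ccn1`, which in this assay gives 2830 nM. The two differ only in the group on the aromatic nitrogen, and the step of a 3.6-fold higher number from compound 1 to compound 2 (0.56 log units; beyond the scatter) shows that such a swap is able to move the read-out by a modest, beyond-scatter amount.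

Compound 3 `CNC(=O)c1cc(Oc2ccc(NC(=O)c3nn(-c4ccc(C)cc4)c(=O)cc3C)cc2F)ccn1` is the next member of the series. It differs from compound 2 as follows: 4-methylphenyl in place of 3-fluorophenyl on an aromatic nitrogen. Going by the values given here, this is again a replacement of the whole aryl group on that aromatic nitrogen, so the only measured step that bears on it is the one from compound 1 to compound 2, which was modest in size. Among the compounds with values here, with one such step to go on, and no direct precedent for a methyl group here, a step of no more than modest size is expected from compound 2 to compound 3, in either direction, as a 1.5-fold lower number from compound 2 to compound 3 (0.16 log units; within the scatter) expresses. Compound 3 is therefore estimated to give 7000 nM in this assay, in a range from 2500 nM to 20000 nM.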

Compound 3, half-maximal inhibitory concentration: 10600 nM
Beside the measured number, compound 3's estimate is 1.5-fold (0.18 log units) below it; low and high end bracket the measured number.
By their numbers in this assay, from the lowest: compound 1; then compounds 2 and 3 (each within the scatter of the next).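

Replacing the 3-fluorophenyl group with the 4-methylphenyl group on the aromatic nitrogen leaves the read-out in this assay essentially unchanged, with a 1.0-fold higher number from compound 2 to compound 3 (0.02 log units; within the scatter) as the whole of the step. This shows something the first pair could not: two different aryl groups at this position, one carrying fluorine and the other a methyl group at a different place on the ring, cannot be told apart here. Compound 1 now stands apart from both, with a 3.7-fold higher number from compound 1 to compound 3 (0.57 log units; beyond the scatter) matching in size the earlier 3.6-fold higher number from compound 1 to compound 2 (0.56 log units; beyond the scatter), so the 4-bromo-2-fluorophenyl group is the only one of the three that separates from the others in this read-out.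

The compounds shown leave open whether the bromine or the fluorine of compound 1 goes with its lower number, and how an aryl ring bearing an amine or a carboxylic acid, or a plain alkyl chain in place of the aryl group, would read at this nitrogen in this assay. Nothing at hand speaks to why these three aryl groups read as they do.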